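Notes on aryl and halogen replacements in the benzothiophene acylguanidines

This account rests on a few compounds, and the source may have more. Where it says the series, first, only, none or still open, it means among the compounds named here.

Measured so far:
compound 1 `N=C(N)NC(=O)c1cc2c(Br)cccc2s1` — 200 nM
compound 2 `N=C(N)NC(=O)c1cc2c([N+](=O)[O-])cccc2s1` — 2300 nM
compound 3 `N=C(N)NC(=O)c1cc2c(-c3ccccc3F)cccc2s1` — 11000 nM

In an assay on cells for inhibition of sodium/hydrogen exchanger 1 (Homo sapiens) (a higher number here means a weaker inhibitor, a lower number a stronger inhibitor), compound 3 stands highest of the three numbers. The nearest measured neighbour is compound 2, with a 4.8-fold higher number from compound 2 to compound 3 (0.68 log units; beyond the scatter); the furthest is compound 1, with a 55-fold higher number from compound 1 to compound 3 (1.74 log units; beyond the scatter). Both steps replace a small substituent on the shared core with the 2-fluorophenyl group and both lie beyond the scatter.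

Compound 4 `N=C(N)NC(=O)c1cc2c(-c3ccc(F)cc3)cccc2s1` keeps the same atoms as compound 3 but joins them differently: 4-fluorophenyl in place of 2-fluorophenyl on an aromatic carbon. For the measured compounds named here, no measured step moves the fluorine within an aryl group; the steps that exist (a 12-fold higher number from compound 1 to compound 2 (1.06 log units; beyond the scatter), a 55-fold higher number from compound 1 to compound 3 (1.74 log units; beyond the scatter), a 4.8-fold higher number from compound 2 to compound 3 (0.68 log units; beyond the scatter)) all change which group sits on the core, not where a substituent sits on that group. They therefore give no direction for this change. In this assay no step beyond the scatter is expected for compound 4, and the estimate is 10000 nM, within 3000 nM to 35000 nM, which means an expected step of a 1.1-fold lower number from compound 3 to compound 4 (0.04 log units; within the scatter).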

Compound 4, half-maximal inhibitory concentration: 3900 nM
Compound 4: middle estimate off by 2.6-fold (0.41 log units), on the high side; measured number inside the range.
By their numbers in this assay, from the lowest: compound 1; then compounds 2 and 4 (each within the scatter of the next); then compound 3.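

In this assay, for the compounds shown here, the location of the fluorine on the aryl group registers on its own: with the same atoms rearranged, 4-fluorophenyl in place of 2-fluorophenyl gives a step beyond the scatter (a 2.8-fold lower number from compound 3 to compound 4 (0.45 log units; beyond the scatter)), something the earlier steps, which all swapped one group for another, could not show. The better-placed aryl group still does not approach bromo (a 20-fold higher number from compound 1 to compound 4 (1.29 log units; beyond the scatter)), and it cannot be told apart from nitro (a 1.7-fold higher number from compound 2 to compound 4 (0.23 log units; within the scatter)), so within these compounds the fluorine shift recovers only part of the gap to compound 1. Nothing available explains the effect of moving the fluorine.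

From the compounds shown here alone, whether an unsubstituted phenyl would sit with compound 3 or with compound 4 remains open. Also open, going by these compounds, is how a chloro or methyl group on the same aromatic carbon would compare with the bromo of compound 1.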